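Difluoromethoxy for Methyl on a Benzamide Anilide: Cytotoxicity Outlook

The source may report more compounds than this note shows. Statements on the series, on what has been measured and on what is new or still open speak of the compounds shown alone.

Compound 1 `O=C(NCC1CCCCC1)c1cccc(/C=C2\CC(=O)N(c3ccccc3)C2=O)c1` — in an ADME assay on NCM460 cells (Homo sapiens) for cytotoxicity, read by MTT assay, with a stated time of 72 h (a higher number here means a weaker inhibitor, a lower number a stronger inhibitor), compound 1 gives only a limit, > 100000 nM.
Compound 2 `CCOc1ccc(NC(=O)c2cccc(/C=C3\CC(=O)N(c4ccccc4)C3=O)c2)cc1` — in this assay compound 2 gives only a limit, > 100000 nM.
Compound 3 `Cc1ccc(NC(=O)c2cccc(/C=C3\CC(=O)N(c4ccccc4)C3=O)c2)cc1` — in this assay compound 3 gives only a limit, > 100000 nM.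

Compound 3 thus stands at the limit of this assay, and the limit of > 100000 nM in this assay, at which 3 of the 3 values shown sit, shows that nothing measured here lies elsewhere. With every value a limit, the steps a step that the two limits leave unreadable from compound 1 to compound 3 and a step that the two limits leave unreadable from compound 2 to compound 3 cannot be sized. Compound 4 `O=C(Nc1ccc(OC(F)F)cc1)c1cccc(/C=C2\CC(=O)N(c3ccccc3)C2=O)c1` differs from compound 3 by difluoromethoxy in place of methyl on an aromatic carbon. Within the data shown here, the only measured step at that aromatic carbon, a step that the two limits leave unreadable from compound 2 to compound 3, is unreadable, so no direction beyond the scatter can be predicted. Compound 4 is therefore expected to give about 100000 nM (range 40000 nM to 300000 nM), most likely again only a limit. The expected step of a number no higher from compound 3 to compound 4 (the limit leaves the size open) is essentially none.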

Compound 4, half-maximal inhibitory concentration: > 100000 nM
Compound 4 ended at the assay's limit; the forecaster's own chance of this, stated with the estimate: 85%; the middle value sits exactly at the limit.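

Compound 4 gives only a limit, as do compound 1, compound 2 and compound 3, so no step among them can be read in this assay: the limit of > 100000 nM in this assay, at which 4 of the 4 values shown sit.

The compounds shown leave open how far each lies beyond that limit, and whether methyl, ethoxy and difluoromethoxy differ at all in this assay.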